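The source may hold more compounds than are shown below. What is called first, only, known or untested is meant among the compounds shown, and "the series" means these compounds.

In an assay on HEK293 cells for positive allosteric modulation of metabotropic glutamate receptor 2 (Rattus norvegicus), read by thallium flux, with a stated time of 2.5 min (a lower number here means a smaller maximal response, a higher number a larger maximal response), compound 3 `Cc1c(OCCCCOc2ccc(C(=O)O)cc2Cl)ccc(C(=O)CC(C)C)c1O` gives 99.5%, the highest of the three numbers measured. Compound 1 `Cc1cc(C(=O)O)ccc1OCCCCOc1ccc(C(=O)CC(C)C)c(O)c1C` gives 83.9% in this assay, and compound 2 `Cc1c(OCCCCOc2ccc(C(=O)O)cc2Cl)ccc(C(=O)CC2CCCC2)c1O` gives 82.2%. Both steps to compound 3 were beyond the scatter: a number 15.6 percentage points higher from compound 1 to compound 3 (beyond the scatter) and a number 17.3 percentage points higher from compound 2 to compound 3 (beyond the scatter). Compound 4 `Cc1c(OCCCCOc2ccccc2C(=O)O)ccc(C(=O)CC(C)C)c1O` differs from compound 3 in one place: 2-carboxyphenyl in place of 4-carboxy-2-chlorophenyl on an oxygen on a saturated carbon. Within the data shown here, of the measured steps only a number 15.6 percentage points higher from compound 1 to compound 3 (beyond the scatter) touches the same chloro, and no step covers a 2-carboxyphenyl, so the bearing is loose; since the change undoes the chloro that a number 15.6 percentage points higher from compound 1 to compound 3 (beyond the scatter) introduced, a modest decrease is expected, as a number 21.5 percentage points lower from compound 3 to compound 4 (beyond the scatter). Compound 4 is therefore estimated at 78%, within a range from 50% to 100%.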

Compound 4, largest response reached (reported as percent of maximum), in percent of the reference or control that the assay uses: 92.4%
Compound 4: middle estimate off by 14.4 percentage points, on the low side; the measured number falls inside the stated range.
By their numbers in this assay, from the lowest: compounds 2, 1, 4 and 3 (each within the scatter of the next, the first and the last beyond it).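

In this assay, the change to 2-carboxyphenyl gives a number 7.1 percentage points lower from compound 3 to compound 4 (within the scatter), and the change from 4-carboxy-2-methylphenyl gives a number 8.5 percentage points higher from compound 1 to compound 4 (within the scatter). The earlier compounds shown here showed only that chloro in place of methyl moved the number beyond the scatter, whereas this ring, carrying neither group, stays within the scatter of both. No measurement shown here accounts for this. The compounds shown leave open whether a primary amide or a tetrazole could stand in place of the carboxylic acid on this ring and keep the maximal response.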